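The compounds below may be only part of what the source reports. "The series", "measured", "known", "first", "only" and "open" are said of these compounds alone.

Measured so far in an assay on isolated protein for inhibition of Maltase-glucoamylase (Homo sapiens), with a stated time of 15 min; on this read-out higher numbers stand for weaker inhibition and lower numbers for stronger inhibition:
compound 1 `O=C(N/N=C/c1cccs1)c1ccc(-c2nc3ccccc3s2)cc1` gives 8480 nM
compound 2 `O=C(N/N=C/c1cccc(O)c1O)c1ccc(-c2nc3ccccc3s2)cc1` gives 11200 nM
compound 3 `COc1cc(/C=N/NC(=O)c2ccc(-c3nc4ccccc4s3)cc2)cc(OC)c1` gives 16200 nM

Compound 3 carries the highest of the three numbers, yet its gaps to compound 2 and to compound 1 both lie within the scatter, so the three compounds cannot be told apart here. Compound 4 `O=C(N/N=C/c1ccc(Cl)cc1)c1ccc(-c2nc3ccccc3s2)cc1` differs from compound 3 in one place: 4-chlorophenyl in place of 3,5-dimethoxyphenyl on a carbon with a double bond to nitrogen. All three measured steps swap the group on that same carbon: a 1.3-fold higher number from compound 1 to compound 2 (0.12 log units; within the scatter), a 1.9-fold higher number from compound 1 to compound 3 (0.28 log units; within the scatter) and a 1.4-fold higher number from compound 2 to compound 3 (0.16 log units; within the scatter). None of them moved the number beyond the scatter. For compound 4 the expected step is therefore a 1.5-fold lower number from compound 3 to compound 4 (0.17 log units; within the scatter) in this assay, nothing beyond the scatter. Compound 4 is estimated at 11000 nM, with a range from 4500 nM to 27000 nM.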

Compound 4, half-maximal inhibitory concentration: 5310 nM
Compound 4: the middle estimate sits 2.1-fold (0.32 log units) above what was measured; low and high end bracket the measured number.
By their numbers in this assay, from the lowest: compounds 4, 1, 2 and 3 (each within the scatter of the next, the first and the last beyond it).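

Among these compounds, this position can move the number after all: 4-chlorophenyl in place of 3,5-dimethoxyphenyl gives a 3.1-fold lower number from compound 3 to compound 4 (0.48 log units; beyond the scatter) and in place of 2,3-dihydroxyphenyl gives a 2.1-fold lower number from compound 2 to compound 4 (0.32 log units; beyond the scatter) as the first steps here beyond the scatter, though both are modest. In place of thiophen-2-yl it gives only a 1.6-fold lower number from compound 1 to compound 4 (0.20 log units; within the scatter) and so leaves those two compounds indistinguishable. No supporting evidence bears on why these steps differ.

Going by these compounds, what a plain phenyl, or a phenyl carrying an amine or a carboxylic acid, would give on this carbon stays open. So does whether changes to the shared core would matter more.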